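Replacing the Nitrophenyl on the Carbonyl Carbon: One Step Ahead

The source may hold more compounds than are shown below. What is called first, only, known or untested is meant among the compounds shown, and "the series" means these compounds.

Compound 1, `O=C(/C=C/c1cccc(OCc2ccccc2)c1)c1ccc([N+](=O)[O-])cc1`: 59300 nM
Compound 2, `O=C(/C=C/c1cccc(OCc2ccccc2)c1)c1ccccc1Br`: 2200 nM

Two measured compounds share one core and differ only in the ring attached to the carbonyl carbon. In an ADME assay on HEK293 cells (Homo sapiens) for cytotoxicity, read by MTT assay, with a stated time of 68 h (a higher number here means a weaker inhibitor, a lower number a stronger inhibitor), compound 1 gives 59300 nM, the highest of the two numbers, while compound 2 gives 2200 nM. Among the measured compounds shown here, the single measured step, a 27-fold lower number from compound 1 to compound 2 (1.43 log units; beyond the scatter), shows that exchanging this ring can move the number a long way.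

Compound 3, `O=C(/C=C/c1cccc(OCc2ccccc2)c1)c1ccc(Cl)c(Cl)c1Cl`, has not yet been measured. It differs from compound 1 by 2,3,4-trichlorophenyl in place of 4-nitrophenyl on a carbonyl carbon. This is not the same change as in the measured step, but it resembles it: the 4-nitrophenyl leaves and a halogen-bearing phenyl enters at the same carbonyl carbon. The step from compound 1 to compound 2 therefore bears on it, and it was large; a move in the same direction is expected for compound 3, though with three chlorines in a different pattern the size is less certain.

For compound 3 the expected value in this assay is 5000 nM, with a range from 1500 nM to 20000 nM. The expected step, a 12-fold lower number from compound 1 to compound 3 (1.07 log units; beyond the scatter), is an estimate, not a measurement.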

Compound 3, half-maximal inhibitory concentration: 2400 nM
Compound 3: middle estimate off by 2.1-fold (0.32 log units), on the high side; the range from low to high includes it.
By their numbers in this assay, from the lowest: compounds 2 and 3 (each within the scatter of the next); then compound 1.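

The change from 4-nitrophenyl to a halogen-bearing phenyl ring on the carbonyl carbon now has a second example: a 25-fold lower number from compound 1 to compound 3 (1.39 log units; beyond the scatter) in this assay is a large step, close in size to the one seen with 2-bromophenyl. The two halogen-bearing rings also end up indistinguishable, since a 1.1-fold higher number from compound 2 to compound 3 (0.04 log units; within the scatter) lies within the scatter, even though one ring carries bromine and the other is 2,3,4-trichlorophenyl. At this position, then, compound 1 stands well apart from both compound 2 and compound 3, and swapping one of these halogen-bearing rings for the other makes no measurable difference in this assay, while the data offer no measured explanation for either step.

From the compounds shown here alone, what remains open is whether halogens are needed at all for the number to sit so far from that of compound 1, or whether losing the 4-nitrophenyl is enough. A plain phenyl ring, or a phenyl ring carrying an amine or a carboxylic acid on the same carbonyl carbon, would help separate these two readings.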